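Removing a Furanylmethyl Group: What Compound 3 Should Tolerate

The source may report more compounds than this note shows. Statements on the series, on what has been measured and on what is new or still open speak of the compounds shown alone.

Compound 1 `O=C(NCc1ccco1)c1ccc(CN2C(=O)c3ccccc3S2(=O)=O)cc1` was tested in an ADME assay on RAW264.7 cells (Mus musculus) for cytotoxicity, read by WST assay; a lower number here means that less compound is tolerated, a higher number that more compound is tolerated. In this assay compound 1 gives > 100000 nM, which is a limit of the assay rather than a measured number. Compound 2 `O=C(c1ccc(Cn2sc3ccccc3c2=O)cc1)N1CCCCC1` was tested in the same way, and in this assay compound 2 gives > 100000 nM, again a limit. Both results sit at the same point: the limit of > 100000 nM in this assay, at which 2 of the 2 values shown sit. Compound 1 therefore stands at the limit, with no measured number above or below it to rank against.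

Compound 3 `NC(=O)c1ccc(CN2C(=O)c3ccccc3S2(=O)=O)cc1` has not yet been measured. It differs from compound 1 by hydrogen in place of (furan-2-yl)methyl on an amide-type nitrogen. Going by the values given here, no measured pair of compounds shows what this kind of change does in this assay. The expected step of a number no higher from compound 1 to compound 3 (the limit leaves the size open) is none beyond the usual scatter. Compound 3 is expected to give 100000 nM, within a range from 50000 nM to 300000 nM, and most likely to be reported again only as a limit.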

Compound 3, concentration lethal to 50% of the cells: > 100000 nM
Compound 3 was reported as a limit; the forecaster's own chance of this, stated with the estimate: 85%; the middle value sits exactly at the limit.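

No step can be read from compound 1 to compound 3, as both are reported in this assay only as a limit: the limit of > 100000 nM in this assay, at which 3 of the 3 values shown sit. The compounds shown leave open at what concentration each one kills the cells, and whether hydrogen in place of (furan-2-yl)methyl on an amide-type nitrogen changes that concentration at all.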